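This account rests on a few compounds, and the source may have more. Where it says the series, first, only, none or still open, it means among the compounds named here.

Of the compounds shown here, three built on a shared core have been measured in an ADME assay on NIH3T3 cells (Mus musculus) for inhibition, read by MTT assay, with a stated time of 48 h; a lower number here means a stronger inhibitor, a higher number a weaker inhibitor. In that test, compound 1 `COc1ccc(-c2nc3ccccn3c2Sc2ccccc2)cc1` gives 91700 nM and compound 3 `Clc1ccc(Sc2c(-c3ccccc3)nc3ccccn23)cc1` gives 88700 nM, so these two numbers lie within the usual scatter of each other. Compound 2 `Cc1ccc2nc(-c3ccc(Cl)cc3)c(Sc3ccccc3)n2c1` is reported only as a limit, > 100000 nM. Among the measured compounds shown here, compound 1 therefore stands level with compound 3, and these are the only two exact numbers available.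

The account now follows the step from compound 1 to compound 4 `c1ccc(Sc2c(-c3ccsc3)nc3ccccn23)cc1`, which has not yet been measured in this assay. Here thiophen-3-yl comes in place of 4-methoxyphenyl on an aromatic carbon, (thiophen-3-yl in place of 4-methoxyphenyl on an aromatic carbon). For the measured compounds named here, no step between measured compounds that differ in one place is available as a guide, so the expectation rests on the level of the existing readings alone. With that in mind, no change beyond the scatter is expected in this assay. The expected step, a 1.1-fold lower number from compound 1 to compound 4 (0.06 log units; within the scatter), is an estimate and carries no firm direction. A result reported only as a limit also remains possible for the new compound. For compound 4 the estimated value is 80000 nM, with an expected range from 40000 nM to 150000 nM.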

Compound 4, half-maximal inhibitory concentration: 94100 nM
Compound 4: middle estimate off by 1.2-fold (0.07 log units), on the low side; measured number inside the range.
By their numbers in this assay, from the lowest: compounds 3, 1 and 4 (each within the scatter of the next). At a limit, above all of these: compound 2.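

Among the compounds shown here, the step, a 1.0-fold higher number from compound 1 to compound 4 (0.01 log units; within the scatter), is the first one between measured compounds that differ in one place, and it gives the first direct reading at this aromatic carbon of the five-membered ring. In this assay, thiophen-3-yl, with five heavy atoms and a sulfur in its ring, takes the place of 4-methoxyphenyl, with eight heavy atoms and a six-membered ring of carbon only, with no change beyond the scatter, so this exchange of one aromatic ring for another leaves the reading where it was. Compound 2 is reported only as a limit, and that limit marks how little room lies above the readings of this series: the limit of > 100000 nM in this assay, at which 1 of the 4 values shown sits.

As far as these compounds go, the result covers just one exchange of aromatic rings, so it remains open whether a carboxylic acid, an amine or a saturated ring such as cyclohexyl at this carbon would move the number in either direction. From the compounds shown here alone, it is also open whether thiophen-3-yl would behave the same way if the phenylsulfanyl group carried a substituent, such as a chlorine atom or a methoxy group.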